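The source may hold more compounds than are shown below. What is called first, only, known or untested is meant among the compounds shown, and "the series" means these compounds.

Measured compounds and their solubility:

- compound 1, `COc1cccc(CNCCCNc2ccnc3cc(Oc4ccccc4)ccc23)c1O`: 14500 nM
- compound 2, `CC(C)Cc1ccc2c(NCCCNCc3ccco3)ccnc2c1`: 4200 nM
- compound 3, `FC(F)(F)c1cc(-c2ccc3c(NCCCNCc4ccco4)ccnc3c2)cc(C(F)(F)F)c1`: 32000 nM

These three compounds were tested in a physicochemical assay for solubility, with a stated time of 18 h, at pH 7.4; on this read-out higher numbers stand for higher solubility and lower numbers for lower solubility. Among the three numbers, compound 2 stands lowest. Its nearest neighbour is compound 1, whose value lies beyond the usual scatter above it, and compound 3 lies further above still, also beyond the scatter. Compound 2 is therefore the least soluble of the three measured compounds.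

Compound 4, `Clc1ccc(Oc2ccc3c(NCCCNCc4ccco4)ccnc3c2)cc1`, has not yet been measured in this assay. It differs from compound 2 in one place: 4-chlorophenoxy in place of isobutyl on an aromatic carbon. Among the measured compounds shown here, no pair of measured compounds shows this exact change, so the size of the step must be judged from the wider picture. Both compounds that carry a larger substituent at the shared core, compound 1 with 14500 nM and compound 3 with 32000 nM, sit above compound 2, and this suggests an upward step rather than a downward one, though its size is uncertain.

For compound 4 a solubility of 9000 nM is expected, with a likely range from 3000 nM to 27000 nM. This expectation means a step of a 2.1-fold higher number from compound 2 to compound 4 (0.33 log units; beyond the scatter), probably just beyond the scatter.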

Compound 4, solubility: 14500 nM
Compound 4: the middle estimate sits 1.6-fold (0.21 log units) below what was measured; the measured number falls inside the stated range.
By their numbers in this assay, from the lowest: compound 2; then compounds 1 and 4 (each within the scatter of the next); then compound 3.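

Read in this assay, this is the first direct measurement of a change at this position: 4-chlorophenoxy in place of isobutyl gives a 3.5-fold higher number from compound 2 to compound 4 (0.54 log units; beyond the scatter). The earlier compounds shown here could only hint at the direction of such a step, as none of them formed a pair differing in one place. Here, the two compounds differ in that one place alone, and replacing a group of 4 heavy atoms and no ring with one of 8 heavy atoms and a six-membered aromatic ring goes with a higher number rather than a lower one, although nothing measured here explains the rise.

The compounds shown leave open which part of the 4-chlorophenoxy group goes with this rise, whether the oxygen, the aromatic ring or the chlorine, and a plain phenoxy group at the same position would be a direct test of the chlorine. Also open, as far as these compounds go, is how the number would move with a group of a different kind at this position, such as an amine or a carboxylic acid.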